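Free pyrazole in place of the methylsulfonyl pyrazole

A few compounds are considered here, and "the series" means these few. Any claim that something is new, unique, unknown or untested is made for them only; others in the source may bear on it.

Measured so far in a functional assay on MV4-11 cells (Homo sapiens) for antiproliferative activity, with a stated time of 6 days, tested at 6.25 uM; a higher number here means a stronger effect of the compound at the concentration tested, a lower number a weaker effect:
compound 1 `CNC(=O)N1CCCc2ccc(NC(=O)c3cccc(-c4cnn(S(C)(=O)=O)c4)c3)cc21` gives 18%
compound 2 `CNC(=O)N1CCCc2ccc(NC(=O)c3ccccc3-c3ccccc3)cc21` gives 60.4%
compound 3 `CNC(=O)N1CCCc2ccc(NC(=O)c3ccc(-c4ccccn4)cc3)cc21` gives 79.2%

Compound 1 stands lowest of the three numbers in this assay. The nearest is compound 2, higher by a margin beyond the usual scatter; the furthest is compound 3, higher still, also beyond the scatter. Going by the values given here, the three share the core and differ in the aryl amide part, but no pair differs in a single place, so no measured step is available to guide the next compound.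

Compound 4 `CNC(=O)N1CCCc2ccc(NC(=O)c3cccc(-c4cn[nH]c4)c3)cc21` is the next compound for this assay. It differs from compound 1 in one place: hydrogen in place of methylsulfonyl on an aromatic nitrogen. Among the compounds with values here, nothing among the measured compounds tests a change of this kind, so the direction rests on the remaining structure alone.

A small upward step is expected, of a size near the edge of the scatter, a number 12 percentage points higher from compound 1 to compound 4 (beyond the scatter). Compound 4 is estimated at 30%, with a range from 8% to 60%. Because compound 1 itself gives only 18% in this assay, the estimate for compound 4 stays well short of the other two measured compounds.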

Compound 4, a percentage reported as inhibition, at one concentration (the size of the read-out at that concentration, not a potency): 77.7%
For compound 4 the middle estimate is 47.7 percentage points below the measured one; measured number outside the range, above it.
By their numbers in this assay, from the lowest: compound 1; then compound 2; then compounds 4 and 3 (each within the scatter of the next).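

Hydrogen in place of methylsulfonyl on the aromatic nitrogen is the first single-place change in the series, and in this assay it produces a large step, a number 59.7 percentage points higher from compound 1 to compound 4 (beyond the scatter). With the rest of the structure identical, the low read-out of compound 1 traces to the 1-(methylsulfonyl)-1H-pyrazol-4-yl group rather than to the shared core or the amide link, while compound 4, with 1H-pyrazol-4-yl in the same place, gives 77.7%. No measurement available here explains the size of this step, so it stands as an observation only.

Still open, going by these compounds, is whether the gain requires the hydrogen on that nitrogen or only the loss of methylsulfonyl, a question that a methyl or an acetyl group on the same nitrogen would address directly. Also open, on these data alone, is whether a longer chain there, such as 2-hydroxyethyl or 2-aminoethyl, keeps the read-out of compound 4, and how that read-out at a single concentration relates to a full potency value.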